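Adding a triazolyl group to compound 1

This account rests on a few compounds, and the source may have more. Where it says the series, first, only, none or still open, it means among the compounds named here.

Compound 1 `COc1c(OC(C)C)cc2occ(-c3csc4ccccc34)c(=O)c2c1OC(C)C` gives > 10000 nM in a functional assay on MCF7 cells (Homo sapiens) for antiproliferative activity, read by sulforhodamine B assay, with a stated time of 72 h (a higher number here means a weaker inhibitor, a lower number a stronger inhibitor), which is a limit and not a number. Compound 2 `COc1c(OC(C)C)cc2occ(-c3ccccc3)c(=O)c2c1OC(C)C` gives > 10000 nM, also a limit. Among the measured compounds shown here, the one measured step, a step that the two limits leave unreadable from compound 1 to compound 2, has no readable size, and the evidence amounts to the limit of > 10000 nM in this assay, at which 2 of the 2 values shown sit. Compound 3 `COc1c(OC(C)C)cc2oc(-n3cncn3)c(-c3csc4ccccc34)c(=O)c2c1OC(C)C` carries 1H-1,2,4-triazol-1-yl in place of hydrogen on an aromatic carbon, next to the ring oxygen (1H-1,2,4-triazol-1-yl in place of hydrogen on an aromatic carbon). For the measured compounds named here, with no sized step to draw on, no change beyond the scatter is expected, and the estimated step is a number no higher from compound 1 to compound 3 (the limit leaves the size open). The expected value for compound 3 is 10000 nM, within an estimated range of 3000 nM to 30000 nM.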

Compound 3, half-maximal inhibitory concentration: > 10000 nM
Compound 3 ended at the assay's limit; the forecaster's own chance of this, stated with the estimate: 60%; the middle value sits exactly at the limit.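

Compound 3, like compound 1, gives only a limit and not a number in this assay, so no size can be read for the step between them. The compounds shown leave open what the 1H-1,2,4-triazol-1-yl group changes.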